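Trifluoromethoxy for trifluoromethylcarbonyl on the amide aryl ring

A few compounds are considered here, and "the series" means these few. Any claim that something is new, unique, unknown or untested is made for them only; others in the source may bear on it.

Three benzamide-type entries have numbers in a functional assay on HEK293 cells for antagonist activity at transient receptor potential cation channel subfamily V member 1 (Homo sapiens), read by calcium flux; a lower number here means a stronger inhibitor, a higher number a weaker inhibitor. Compound 1 `CC(C)(C)c1ccc(NC(=O)c2ccc(OC(F)(F)C(F)F)cc2)cc1` gives 70 nM. Compound 2 `O=C(Nc1ccc(I)cc1)c1ccc(C(=O)C(F)(F)F)cc1` gives 790 nM. Compound 3 `CCC(c1ccccn1)c1c(Cl)c(Cl)cc2[nH]c(=O)c(=O)[nH]c12`, built on a different core, gives 1400 nM. Compound 2 thus stands second highest of the three: its number lies within the scatter of compound 3 and lies above that of compound 1, a gap beyond the scatter.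

The next entry, compound 4 `O=C(Nc1ccc(I)cc1)c1ccc(OC(F)(F)F)cc1`, keeps the iodophenyl amide of compound 2 and changes one group: trifluoromethoxy in place of (trifluoromethyl)carbonyl on an aromatic carbon. For the measured compounds named here, no pair among the measured compounds differs in only this one place, so the size of the step has no direct precedent.

The step in this assay from compound 2 to compound 4 is expected to run toward a lower number, beyond the scatter, a 4.0-fold lower number from compound 2 to compound 4 (0.60 log units; beyond the scatter), because compound 1, whose amide aryl ring carries a fluorinated alkoxy group, gives 70 nM. Compound 4 is therefore estimated at 200 nM in this assay, with a range from 60 nM to 700 nM.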

Compound 4, half-maximal inhibitory concentration: 280 nM
The estimate for compound 4 lay 1.4-fold (0.15 log units) below the measured number; low and high end bracket the measured number.
By their numbers in this assay, from the lowest: compound 1; then compound 4; then compounds 2 and 3 (each within the scatter of the next).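

In this assay, for the compounds shown here, the exchange of (trifluoromethyl)carbonyl for trifluoromethoxy, on an aromatic carbon para to a large group, gives a 2.8-fold lower number from compound 2 to compound 4 (0.45 log units; beyond the scatter) and so provides the first pair that differs in one place only. With the iodophenyl amide held constant, the number therefore shows that this position responds to the group it carries and that the carbonyl of compound 2 is not needed for inhibition in this range, while the change is modest in size and keeps the count of hydrogen-bond acceptors as it was. No measurement on hand bears on what lies behind this step, and it stands as an observation only.

A single pair cannot show whether the same exchange gives a step of similar size when the iodo group of the amide aryl ring is replaced by the tert-butyl group carried by compound 1. On these data alone, how a plain methoxy group, a nitrile or a carboxylic acid would compare at this position also stays open.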